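A few compounds are considered here, and "the series" means these few. Any claim that something is new, unique, unknown or untested is made for them only; others in the source may bear on it.

Measured in a functional assay on SH-SY5Y cells (Homo sapiens) for cytotoxicity, read by MTT assay, with a stated time of 72 h; on this read-out lower numbers stand for stronger inhibition and higher numbers for weaker inhibition:
- compound 1 `[O-][S+](CCCCN=C=S)Cc1ccccc1` gives 5210 nM
- compound 2 `COc1ccc(C[S+]([O-])CCCCN=C=S)cc1` gives 2790 nM

Not yet measured:
- compound 3 `[O-][S+](CCCCCN=C=S)Cc1ccccc1`

For the measured compounds named here, only one measured step exists, a 1.9-fold lower number from compound 1 to compound 2 (0.27 log units; within the scatter), and it lies within the scatter. Going by the values given here, compound 1 therefore stands level with the only other measured value, and no order can be read from the pair. The change under consideration is a group of 4 heavy atoms (2 carbon, 1 nitrogen, 1 sulfur; no ring) in place of a group of 3 heavy atoms (1 carbon, 1 nitrogen, 1 sulfur; no ring), on a saturated chain carbon, four bonds along the chain from a sulfur. The measured step, methoxy in place of hydrogen on an aromatic carbon, falls elsewhere in the molecule. Among the compounds with values here, no measured step alters the chain, so the data give only weak guidance here. No step beyond the scatter is expected in this assay, in either direction. The estimated step is a 1.2-fold lower number from compound 1 to compound 3 (0.06 log units; within the scatter). For compound 3 the expected value is 4500 nM, with an estimated range of 2200 nM to 9000 nM.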

Compound 3, half-maximal inhibitory concentration: 7010 nM
Beside the measured number, compound 3's estimate is 1.6-fold (0.19 log units) below it; measured number inside the range.
By their numbers in this assay, from the lowest: compounds 2, 1 and 3 (each within the scatter of the next, the first and the last beyond it).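

For the compounds shown here, the step of a 1.3-fold higher number from compound 1 to compound 3 (0.13 log units; within the scatter) is the first reading on the chain itself in this assay and concerns a group of 4 heavy atoms in place of a group of 3 heavy atoms, on a saturated chain carbon, four bonds along the chain from a sulfur. The extra carbon therefore leaves compound 1 and compound 3 level on this read-out, so this position accepts the change without a step beyond the scatter, though a single step sets no trend with chain length. No supporting data bear on why the two compounds stand level.

Still open, from the compounds shown here alone, is whether a longer chain at this place would stay level with compound 1 or move beyond the scatter. Equally open, going by these compounds, is how an amine or a carboxylic acid at the chain end would read in this assay on the core of compound 1.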